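From Isopropyl to Methylcarbamoyl on the Core

A few compounds are considered here, and "the series" means these few. Any claim that something is new, unique, unknown or untested is made for them only; others in the source may bear on it.

Compound 1, `Clc1ccccc1-c1ccc2[nH]ncc2c1`: 1230 nM
Compound 2, `CC(C)(C)c1ccccc1-c1ccc2[nH]ncc2c1`: 3400 nM
Compound 3, `CC(C)c1cc2[nH]ncc2cc1-c1ccccc1C(F)(F)F`: 25400 nM

In an assay on CHO-TREX cells for antagonist activity at transient receptor potential cation channel subfamily A member 1 (Homo sapiens), read by FLIPR and calcium flux, with a stated time of 10 min (on this read-out lower numbers stand for stronger inhibition and higher numbers for weaker inhibition), compound 3 stands highest of the three numbers, the least potent of the measured set: its number sits well beyond the scatter above that of compound 2 and further still above that of compound 1. Among the compounds with values here, the only single-site step measured is a 2.8-fold higher number from compound 1 to compound 2 (0.44 log units; beyond the scatter), a change on the other ring, not on the core.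

Compound 4, `CNC(=O)c1cc2[nH]ncc2cc1-c1ccccc1C(F)(F)F`, differs from compound 3 by methylcarbamoyl in place of isopropyl on an aromatic carbon. Within the data shown here, no measured step touches this position, and compounds 1 and 2 carry no group there at all, so the data give no direct guide. With the core substituent exchanged for a group of similar size that now carries a hydrogen-bond donor and acceptor, a shift in either direction is plausible and none beyond the scatter is firmly expected. Compound 4 is estimated at 15000 nM, with a range from 3000 nM to 60000 nM, meaning an expected step of a 1.7-fold lower number from compound 3 to compound 4 (0.23 log units; within the scatter).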

Compound 4, half-maximal inhibitory concentration: > 30000 nM
Compound 4: only a limit was reported; the forecaster's own chance of this, stated with the estimate: 25%; at least 2.0-fold (0.30 log units) between middle value and limit.
By their numbers in this assay, from the lowest: compound 1; then compound 2; then compound 3. At a limit, above all of these: compound 4.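

Compound 4 gives only a limit rather than a number in this assay: the limit of > 30000 nM in this assay, at which 1 of the 4 values shown sits. Exchanging isopropyl for methylcarbamoyl on this aromatic carbon gives an at least 1.1-fold higher number from compound 3 to compound 4 (0.07 log units; that floor lies within the scatter), so the true size of the step cannot be read and may be small or large. This first change at the position shows that bringing in a hydrogen-bond donor and acceptor, which isopropyl lacks, yields no stronger inhibition than compound 3 gives.

One change at one position cannot show which part of methylcarbamoyl matters, or whether any group on this carbon can improve inhibition. Still open, from the compounds shown here alone, is how an amine, a carboxylic acid or a longer chain would read here, and how the shared core with trifluoromethyl on the other ring would read with only hydrogen on this carbon.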